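Working notes: the step from compound 1 to compound 4

The compounds below may be only part of what the source reports. "The series", "measured", "known", "first", "only" and "open" are said of these compounds alone.

Measured in an ADME assay on BJ cells (Homo sapiens) for cytotoxicity, with a stated time of 72 h; on this read-out lower numbers stand for an effect already at smaller amounts and higher numbers for an effect only at larger amounts of compound:
- compound 1 `C=C[C@@](C)(/C=C/c1ccc(OS(=O)(=O)C(F)(F)F)cc1)CCC=C(C)C`: > 36600 nM, a limit
- compound 2 `C=C[C@@](C)(/C=C/c1ccc(OS(=O)(=O)c2ccc(C)cc2)cc1)CCC=C(C)C`: > 36600 nM, a limit
- compound 3 `C=C[C@@](C)(/C=C/c1ccc(O)c(/C=C/c2ccc(Cl)c(Cl)c2)c1)CCC=C(C)C`: > 13000 nM, a limit

Compound 1 stands at a limit and has no numerical value. All the other readings are limits too, so compound 1 cannot be ranked against them.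

Compound 4 `C=C[C@@](C)(/C=C/c1ccc(Nc2cc(F)cc(F)c2)cc1)CCC=C(C)C` keeps the core of compound 1 and carries (3,5-difluorophenyl)amino in place of ((trifluoromethyl)sulfonyl)oxy on an aromatic carbon, para to a large group ((3,5-difluorophenyl)amino in place of ((trifluoromethyl)sulfonyl)oxy on an aromatic carbon).

Among the compounds with values here, the one measured step that bears on this change is a step that the two limits leave unreadable from compound 1 to compound 2. It alters the same substituent, with 4-methylphenyl in place of trifluoromethyl on a sulfonyl sulfur, but it gives no size to carry over. Compound 3 shows no effect within its tested range either, and its reading remains a limit.

With no effect yet read in this set, only a modest change is expected in this assay, if any, and the direction can only be toward smaller amounts. The expected step is an at least 1.4-fold lower number from compound 1 to compound 4 (0.16 log units; that floor lies within the scatter), and another limit would not be a surprise. For compound 4 the estimated value is 25000 nM, with an expected range from 8000 nM to 50000 nM.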

Compound 4, half-maximal effective concentration: > 36600 nM
Compound 4 was reported as a limit; the forecaster's own chance of this, stated with the estimate: 65%; middle value at least 1.4-fold (0.16 log units) from the limit.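

In this assay compound 4 gives > 36600 nM, which is a limit. Within the data shown here, compound 1 also stands at a limit, so no step between compound 1 and compound 4 can be read. The compounds shown leave open whether any of them has a measurable effect in this assay, and how large a change of this substituent on the aromatic carbon would be.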